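Replacing the phenyl-bearing amidine with a salicylamide group

This account rests on a few compounds, and the source may have more. Where it says the series, first, only, none or still open, it means among the compounds named here.

Measured so far:
Compound 1, `N#CC1=C(NCC(=O)N2CCOCC2)N(c2ccccc2)C(=O)N2CCCCC(N3CCCC3)C12`, gives 69.8%.
Compound 2, `N#CC1=C(/N=C/Nc2ccccc2)N(c2ccccc2)C(=O)N2CCCCC(N3CCCC3)C12`, gives 47.5%.

Both numbers come from a functional assay on the whole organism (strain albino) for inhibition, with Rattus norvegicus as the target, read by paw edema, with stated times of 1 h and 2 h, at a dose of 20 mmol/kg by the intraperitoneal route; a higher number here means more inhibition at the dose given (going by the name of the read-out), a lower number less inhibition. For the measured compounds named here, compound 2 stands lowest of the two measured values; its nearest neighbour, compound 1, lies a number 22.3 percentage points lower from compound 1 to compound 2 (beyond the scatter), the only step that can be read so far.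

Compound 3, `N#CC1=C(NC(=O)c2ccccc2O)N(c2ccccc2)C(=O)N2CCCCC(N3CCCC3)C12`, has not been measured. It differs from compound 2 at one spot on the shared core: a group of 10 heavy atoms (7 carbon, 1 nitrogen, 2 oxygen; one six-membered aromatic ring of carbon only) in place of a group of 9 heavy atoms (7 carbon, 2 nitrogen; one six-membered aromatic ring of carbon only), on a double-bonded ring carbon The entering group is the ((2-hydroxyphenyl)carbonyl)amino group, and it sits on a double-bonded ring carbon of the six-membered non-aromatic ring with two nitrogen atoms.

Going by the values given here, the one step that bears on this change is the step from compound 1 to compound 2: there, a group holding two oxygen atoms gave way to one holding two nitrogen atoms and no oxygen, and the reading fell by a modest amount beyond the scatter. The change from compound 2 to compound 3 runs partly the other way, bringing back two oxygen atoms and an amide-type carbonyl. Among the compounds with values here, a rise of modest size is therefore expected, a number 12.5 percentage points higher from compound 2 to compound 3 (beyond the scatter), though the new group is not the same as the one in compound 1, so full return is not assumed.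

Compound 3 is expected to give 60%, with a likely range from 45% to 75%.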

Compound 3, a percentage reported as inhibition, in the whole organism at one dose (the size of the read-out at that dose, not a potency): 53.8%
Compound 3: the middle estimate sits 6.2 percentage points above what was measured, within the range that was stated.
By their numbers in this assay, from the lowest: compounds 2 and 3 (each within the scatter of the next); then compound 1.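

In this assay the reading stands a number 6.3 percentage points higher from compound 2 to compound 3 (within the scatter), so at this double-bonded ring carbon the ((2-hydroxyphenyl)carbonyl)amino group cannot be told apart from the oxygen-free group it replaces, even though the two differ in make-up. The other new step, a number 16 percentage points lower from compound 1 to compound 3 (beyond the scatter), is beyond the scatter: with (2-hydroxyphenyl)carbonyl in place of ((morpholin-4-yl)carbonyl)methyl on the amine nitrogen, the presence of two oxygen atoms in the group is not enough to match the higher reading of the morpholine-bearing compound. No measurement at hand explains why these groups read as they do.

The compounds shown leave open which part of the ((morpholin-4-yl)carbonyl)methyl group goes with the higher reading, a question that a (piperidin-1-yl)carbonylmethyl group, with a carbon in place of the morpholine ring oxygen, could help to settle. They also leave open whether the ring hydroxyl matters in the (2-hydroxyphenyl)carbonyl group, which a plain benzoyl group or a (2-methoxyphenyl)carbonyl group would test at this same position.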